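The compounds below may be only part of what the source reports. "The series", "measured", "known", "first", "only" and "open" are said of these compounds alone.

Compound 1 `Cc1ncc(-c2ccccc2NCC2=NCCN2)o1` gives, in a functional assay for activation of Alpha-1B adrenergic receptor (Homo sapiens), read by calcium flux (on this read-out higher numbers stand for an effect only at larger amounts of compound and lower numbers for an effect already at smaller amounts), < 5020 nM.
Compound 2 `Cc1noc(-c2ccccc2NCC2=NCCN2)n1` gives, in this assay, < 5020 nM.

The value of compound 1 is a limit of the assay, not a number. The value of compound 2 is likewise a limit of the assay. Compound 2 therefore stands only at a limit, and the step that the two limits leave unreadable from compound 1 to compound 2 cannot be read in size, since both values sit at the same limit (the limit of < 5020 nM in this assay, at which 2 of the 2 values shown sit).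

Compound 3 `c1ccc(-c2cnccn2)c(NCC2=NCCN2)c1` differs from compound 2 by pyrazin-2-yl in place of 3-methyl-1,2,4-oxadiazol-5-yl on an aromatic carbon. Within the data shown here, no measured step bears readably on this change; the only step in hand is the unreadable one from the first pair. He expects compound 3 to remain on the active side of that limit, with an estimated step that the limit leaves unreadable from compound 2 to compound 3 that carries no clear direction. His estimate for compound 3 in this assay is 1200 nM, with a range from 150 nM to 5000 nM.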

Compound 3, half-maximal effective concentration: 339 nM
For compound 3 the middle estimate is 3.5-fold (0.55 log units) above the measured one; the range from low to high includes it.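

Neither the step from compound 1 to compound 3 nor the step from compound 2 to compound 3 can be read in size, because the values of compound 1 and compound 2 are limits of the assay: the limit of < 5020 nM in this assay, at which 2 of the 3 values shown sit.

The compounds shown leave open how the pyrazin-2-yl group truly compares with either five-membered ring group in this assay.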